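Series notes: fluoro for chlorophenoxy at the aryl terminus

The compounds below may be only part of what the source reports. "The series", "measured", "known", "first", "only" and "open" are said of these compounds alone.

Measured so far in an assay on isolated protein for inhibition of Bile acid receptor (Homo sapiens), read by TR-FRET and LanthaScreen; a higher number here means a weaker inhibitor, a lower number a stronger inhibitor:
Compound 1 `CC(C)C[C@@H](c1nc2ccc(C(=O)O)cc2n1C)N1CCN(c2ccc(Oc3ccccc3)cc2)C1=O` gives 28500 nM.
Compound 2 `CC(C)C[C@@H](c1nc2ccc(C(=O)O)cc2n1C)N1C(=O)CN(c2ccc(Oc3ccccc3)cc2)C1=O` gives 43400 nM.
Compound 3 `CC(C)C[C@@H](c1nc2ccc(C(=O)O)cc2n1C)N1C(=O)CN(c2ccc(Oc3ccc(Cl)cc3)cc2)C1=O` gives 2560 nM.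

Compound 3 stands lowest of the three numbers in this assay; its nearest neighbour is compound 1, and compound 2 lies furthest. Going by the values given here, the only single-point step measured is a 17-fold lower number from compound 2 to compound 3 (1.23 log units; beyond the scatter), and it bears on the next change only in part: compound 4 `CC(C)C[C@@H](c1nc2ccc(C(=O)O)cc2n1C)N1C(=O)CN(c2ccc(F)cc2)C1=O` differs from compound 3 by fluoro in place of 4-chlorophenoxy on an aromatic carbon, so the whole group whose chloro drove that step is gone. Nothing measured shows the bare fluoro on this ring, so the expectation leans on compound 2, whose value 43400 nM marks the series without chloro. Compound 4 is therefore expected to give 40000 nM, within 10000 nM to 150000 nM, an expected step of a 16-fold higher number from compound 3 to compound 4 (1.19 log units; beyond the scatter).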

Compound 4, half-maximal inhibitory concentration: 399000 nM
Beside the measured number, compound 4's estimate is 10-fold (1.00 log units) below it, and the stated range ends below it.
By their numbers in this assay, from the lowest: compound 3; then compounds 1 and 2 (each within the scatter of the next); then compound 4.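

Most of the binding signal in this series depends on the group at this aromatic carbon: even without the chloro, replacing phenoxy with fluoro gives a 9.2-fold higher number from compound 2 to compound 4 (0.96 log units; beyond the scatter) and a modest loss. With the chloro also gone, the loss widens to a 160-fold higher number from compound 3 to compound 4 (2.19 log units; beyond the scatter), so the outer aromatic ring contributes on top of the chloro gain. No measured evidence gives a reason for either step.

Open, from the compounds shown here alone, is whether the ether oxygen is needed, which a benzyl group here would test, and whether methoxy retains any of the loss.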